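The compounds below may be only part of what the source reports. "The series", "measured", "known", "first", "only" and "open" are said of these compounds alone.

Compound 1, `COCc1ncc2cnnc(SC)n12`: in a functional assay for inhibition, with Homo sapiens as the target (on this read-out higher numbers stand for weaker inhibition and lower numbers for stronger inhibition), compound 1 gives > 48000 nM, a limit of the assay rather than a number.
Compound 2, `CNc1nncc2cncn12`: in this assay compound 2 gives > 48000 nM, again a limit.
Compound 3, `Sc1nncc2cncn12`: in this assay compound 3 gives > 48000 nM, also a limit.

Compound 3 thus stands at the limit of > 48000 nM in this assay, at which 3 of the 3 values shown sit, without a number of its own. Within the data shown here, the only step that reaches it, a step that the two limits leave unreadable from compound 2 to compound 3, cannot be read in size. Compound 4, `COCc1ncc2cnnc(S)n12`, differs from compound 3 by methoxymethyl in place of hydrogen on an aromatic carbon. Among the measured compounds shown here, no measured step tests this change on its own; compound 1 carries the same methoxymethyl group and also sits at the limit. With three limits and one unreadable step, the expectation for compound 4 is no readable step beyond the scatter, a step that the limit leaves unreadable from compound 3 to compound 4, most probably another limit. Compound 4 is therefore estimated at 60000 nM, within 20000 nM to 200000 nM.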

Compound 4, half-maximal inhibitory concentration: > 48000 nM
Compound 4 was reported as a limit; the forecaster's own chance of this, stated with the estimate: 80%; the middle value lies beyond the limit too.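

Compound 4 sits at the limit of this assay, as compound 1 and compound 3 do, so neither step reaching compound 4 can be read in size. The compounds shown leave open which change, if any, would give a measurable value.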